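Swapping chloro for fluoro on a shared benzyl thioether

The source may report more compounds than this note shows. Statements on the series, on what has been measured and on what is new or still open speak of the compounds shown alone.

Measured compounds:
Compound 1, `CC1=C(C(=O)Nc2ccc(F)cc2)C(c2ccc([N+](=O)[O-])cc2)N=C(SCc2ccc(Cl)cc2)N1`: 16%
Compound 2, `CC1=C(C(=O)Nc2ccc(F)cc2)C(c2ccc([N+](=O)[O-])cc2)N=C(SCc2ccc(F)cc2)N1`: 17%
Compound 3, `COc1ccc(C2N=C(SCc3ccc(Cl)cc3)NC(C)=C2C(=O)Nc2ccc(Br)cc2)cc1`: 16.5%

All three numbers come from a functional assay on the whole organism (artery, strain albino) with Rattus norvegicus as the target, with a stated time of 120 min, at a dose of 10 mg/kg by the oral route; a lower number here means less inhibition, a higher number more inhibition at the dose given (going by the name of the read-out). Compound 1 and compound 2 are a pair differing in one place: fluoro in place of chloro on an aromatic carbon. The step is a number 1 percentage points higher from compound 1 to compound 2 (within the scatter), so the two values show no real separation.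

Compound 3 carries a different core; the difference between the core of compound 3 and the core of compound 1 is not broken down here. Compound 3 gives a value close to the others, and the numbers of the three compounds are level within this assay.

The unmeasured compound 4, `COc1ccc(C2N=C(SCc3ccc(F)cc3)NC(C)=C2C(=O)Nc2ccc(Br)cc2)cc1`, relates to compound 3 the way compound 2 relates to compound 1: fluoro in place of chloro on an aromatic carbon. The place described for both changes is the same, so this is the same kind of change made on a different core.

Among the compounds with values here, since the one measured instance of this change, a number 1 percentage points higher from compound 1 to compound 2 (within the scatter), stayed within the scatter, compound 4 is expected to land near compound 3, with a step estimated as a number 1 percentage points higher from compound 3 to compound 4 (within the scatter). Within the data shown here, compound 4 is therefore estimated at 17.5% in this assay, with a likely range from 9% to 26%; this rests on only one prior pair and on a core not measured with the fluoro group.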

Compound 4, a percentage reported as inhibition, in the whole organism at one dose (the size of the read-out at that dose, not a potency): 12.9%
The estimate for compound 4 lay 4.6 percentage points above the measured number; the measured number falls inside the stated range.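

In this assay, putting fluoro in place of chloro on the benzyl thioether of compound 3 gives a number 3.6 percentage points lower from compound 3 to compound 4 (within the scatter), so on this core the two values show no real separation. Within the data shown here, the same swap on the core of compound 1 also stayed within the scatter, and the two steps cannot be told apart, which means the change behaves alike on both cores as far as this assay can tell: the same change on two cores in this assay, a number 1 percentage points higher (within the scatter) from compound 1 to compound 2 and a number 3.6 percentage points lower (within the scatter) from compound 3 to compound 4, 4.6 percentage points apart, within the scatter of two such steps This does not show that the swap is without effect on every core, since it rests on only two pairs, and each value is the size of the response at a single dose rather than a potency, so a small real effect could remain hidden in the scatter.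

As far as these compounds go, what remains open is whether a different group at this spot, para to a large group, such as a nitrile or an amine, would give a step beyond the scatter. Also open, from the compounds shown here alone, is whether replacing the thioether's benzyl group with a longer chain, or adding a carboxylic acid elsewhere on the molecule, would separate any compound from this level set of numbers.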